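A few compounds are considered here, and "the series" means these few. Any claim that something is new, unique, unknown or untested is made for them only; others in the source may bear on it.

In a functional assay on HT-29 cells (Homo sapiens) for inhibition, read by luminescence and CellTiter-Glo, with a stated time of 24 h (on this read-out lower numbers stand for an effect already at smaller amounts and higher numbers for an effect only at larger amounts of compound), compound 3 (`CN1C(=S)[C@@H](NC(=O)c2nc(Cc3ccccc3)n(CC3COC3)n2)COc2ccccc21`) gives 2830 nM. Compound 2 (`CN1C(=S)[C@@H](NC(=O)c2nc(Cc3ccccc3)n(C3CCCC3)n2)COc2ccccc21`) gives 3530 nM, and compound 1 (`CCn1nc(C(=O)N[C@H]2COc3ccccc3N(C)C2=S)nc1Cc1ccccc1`) gives 17 nM. Compound 3 therefore sits level with compound 2 and far from compound 1.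

Compound 4 (`Cc1cnc(-n2nc(C(=O)N[C@H]3COc4ccccc4N(C)C3=S)nc2Cc2ccccc2)nc1`) carries 5-methylpyrimidin-2-yl in place of (oxetan-3-yl)methyl on an aromatic nitrogen of a five-membered aromatic ring with 3 nitrogen: 5-methylpyrimidin-2-yl in place of (oxetan-3-yl)methyl on an aromatic nitrogen.

All three measured steps concern this same nitrogen. The two steps away from ethyl are large: a 210-fold higher number from compound 1 to compound 2 (2.32 log units; beyond the scatter) and a 170-fold higher number from compound 1 to compound 3 (2.22 log units; beyond the scatter). By contrast, the step between the two replacement groups is small: a 1.2-fold lower number from compound 2 to compound 3 (0.10 log units; within the scatter). Among these three compounds, only the ethyl compound stands apart. No aromatic group on this nitrogen has been measured, so the data fix the outcome only loosely.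

The working expectation in this assay is that compound 4 stays near the level of compound 3, with no step beyond the scatter. The estimated step is a 1.4-fold lower number from compound 3 to compound 4 (0.15 log units; within the scatter).

For compound 4 the estimated value is 2000 nM, with an expected range from 200 nM to 10000 nM.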

Compound 4, half-maximal effective concentration: 1950 nM
Estimate against measurement, compound 4: 1.0-fold (0.01 log units) above, within the range that was stated.
By their numbers in this assay, from the lowest: compound 1; then compounds 4, 3 and 2 (each within the scatter of the next).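

In this assay, an aromatic group on this nitrogen falls in with the two non-aromatic replacements: 5-methylpyrimidin-2-yl stays level with (oxetan-3-yl)methyl (a 1.5-fold lower number from compound 3 to compound 4 (0.16 log units; within the scatter)) and with cyclopentyl (a 1.8-fold lower number from compound 2 to compound 4 (0.26 log units; within the scatter)), while the step from ethyl remains large (a 110-fold higher number from compound 1 to compound 4 (2.06 log units; beyond the scatter)). Across these four compounds, three quite different groups on this nitrogen, one of them a six-membered aromatic ring with 2 hetero atoms, all stand apart from ethyl in compound 1, and no compound here goes against that. No measured property bears on why these replacements sit together, so the finding remains descriptive.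

From the compounds shown here alone, whether the low number belongs to ethyl alone remains open. Methyl, n-propyl or 2-methoxyethyl on this nitrogen would show how narrowly the position is defined.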